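Extending the Unsaturated Chain of Compound 3

This account rests on a few compounds, and the source may have more. Where it says the series, first, only, none or still open, it means among the compounds named here.

Compound 3 `COc1ccc(Nc2nc(Oc3cccc(NC(=O)C=C(C)C)c3)c3sccc3n2)cn1` is one of three compounds tested in a functional assay on MCF7 cells (Homo sapiens) for inhibition, read by MTT assay, with a stated time of 72 h; on this read-out lower numbers stand for stronger inhibition and higher numbers for weaker inhibition. In this assay compound 3 gives only a limit, > 100000 nM, and no number. Compound 1 `COc1ccc(Nc2nc(Oc3cccc(NC(=O)/C=C/C(C)C)c3)c3sccc3n2)cc1` likewise gives only a limit in this assay, > 50000 nM. Going by the values given here, compound 2 `COc1cccc(Nc2nc(Oc3cccc(NC(=O)/C=C/C(C)C)c3)c3sccc3n2)c1` gives 43900 nM in this assay; the step of an at least 1.1-fold lower number from compound 1 to compound 2 (0.05 log units; that floor lies within the scatter) is the only measured step, and it changes the group on a nitrogen on an aromatic ring, not the chain. Compound 4 `COc1ccc(Nc2nc(Oc3cccc(NC(=O)/C=C/C(C)C)c3)c3sccc3n2)cn1` differs from compound 3 by 3-methylbut-1-en-1-yl in place of 2-methylprop-1-en-1-yl on a carbonyl carbon. Among the compounds with values here, no measured step bears on this change; compounds 1 and 2, which carry the entering chain, sit at the limit of > 50000 nM in this assay, at which 1 of the 3 values shown sits, or near it. Compound 4 is therefore expected to show an at least 1.2-fold lower number from compound 3 to compound 4 (0.09 log units; that floor lies within the scatter), and its value in this assay is estimated at 80000 nM (range 30000 nM to 200000 nM), quite possibly a limit again.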

Compound 4, half-maximal inhibitory concentration: > 50000 nM
Compound 4: only a limit was reported; the forecaster's own chance of this, stated with the estimate: 60%; the middle value does not contradict the limit.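

Compound 4 also ends at a limit in this assay: the limit of > 50000 nM in this assay, at which 2 of the 4 values shown sit. Compound 3 is likewise a limit: the limit of > 100000 nM in this assay, at which 1 of the 4 values shown sits. Going by these compounds alone, the steps from compound 3 and from compound 1 to compound 4 cannot be read, so the effect of 3-methylbut-1-en-1-yl in place of 2-methylprop-1-en-1-yl stays unknown, and the only readable step is an at least 1.1-fold higher number from compound 2 to compound 4 (0.05 log units; that floor lies within the scatter) for 6-methoxypyridin-3-yl in place of 3-methoxyphenyl.

From the compounds shown here alone, whether a longer chain or an amine on the carbonyl carbon would give a measurable number in this assay remains open.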